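The source may report more compounds than this note shows. Statements on the series, on what has been measured and on what is new or still open speak of the compounds shown alone.

Measured in a functional assay on SGC-7901 cells (Homo sapiens) for inhibition, read by MTT assay, with a stated time of 24 h; a lower number here means a stronger inhibitor, a higher number a weaker inhibitor:
compound 1, `CC1(C)[C@H]2CC[C@]1(C)N(Cc1cn(-c3ccccc3Br)nn1)C(=O)C2`, 500 nM;
compound 2, `CC1(C)[C@H]2CC[C@]1(C)N(Cc1cn(-c3ccccc3Cl)nn1)C(=O)C2`, 220 nM;
compound 3, `Cc1ccccc1-n1cc(CN2C(=O)C[C@@H]3CC[C@@]2(C)C3(C)C)nn1`, 350 nM.

Compound 2 carries the lowest of the three numbers. One of its steps is a 2.3-fold lower number from compound 1 to compound 2 (0.36 log units; beyond the scatter), beyond the scatter, while the other, a 1.6-fold higher number from compound 2 to compound 3 (0.20 log units; within the scatter), is within the scatter, so compound 2 and compound 3 cannot be ordered against each other on these numbers. Compound 1 to compound 3 gives a 1.4-fold lower number from compound 1 to compound 3 (0.15 log units; within the scatter), also within the scatter.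

Compound 4 is `COc1cccc(-n2cc(CN3C(=O)C[C@@H]4CC[C@@]3(C)C4(C)C)nn2)c1`. Relative to compound 2 the change is 3-methoxyphenyl in place of 2-chlorophenyl on an aromatic nitrogen. Within the data shown here, none of the measured steps bears directly on it: all three compare chloro, bromo and methyl at the same place on the phenyl, and no compound carries a methoxy or a group elsewhere on that ring. What the measured steps do show is that varying this phenyl moves the number only modestly, with the largest step, a 2.3-fold lower number from compound 1 to compound 2 (0.36 log units; beyond the scatter), just beyond the scatter. A change that removes the chloro and moves the substituent is therefore expected to cost little to a moderate amount rather than to gain, with a wider range than a plain swap at the same place would carry. The step expected is a 1.8-fold higher number from compound 2 to compound 4 (0.26 log units; within the scatter). Compound 4 is estimated at 400 nM, with a range of 150 nM to 1100 nM.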

Compound 4, half-maximal inhibitory concentration: 590 nM
Compound 4: the middle estimate sits 1.5-fold (0.17 log units) below what was measured, within the range that was stated.
By their numbers in this assay, from the lowest: compounds 2, 3, 1 and 4 (each within the scatter of the next, the first and the last beyond it).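

In this assay, among these compounds, 3-methoxyphenyl is the only group here on the aromatic nitrogen that carries a hydrogen-bond acceptor and has its substituent away from the place held by chloro, bromo and methyl, and set against 2-chlorophenyl it gives a 2.7-fold higher number from compound 2 to compound 4 (0.43 log units; beyond the scatter). Against the other two groups it does not separate, with a 1.7-fold higher number from compound 3 to compound 4 (0.23 log units; within the scatter) and a 1.2-fold higher number from compound 1 to compound 4 (0.07 log units; within the scatter), so compound 2 is the only compound in the set that compound 4 stands apart from, and this position tolerates a different kind of substituent in a different place without leaving the band set by compound 1 and compound 3. The compounds come with no measurement that accounts for this step.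

On these data alone, the group and its place change together in the step from compound 2 to compound 4, so the share of each stays open until a methoxy sits where the chloro sits in compound 2, or a chloro where the methoxy sits in compound 4. Also open, as far as these compounds go, is how this position answers to a plain phenyl, or to an amine or a carboxylic acid on that ring.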